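The source may hold more compounds than are shown below. What is called first, only, known or untested is meant among the compounds shown, and "the series" means these compounds.

Measured in a functional assay on Jurkat cells (Homo sapiens); on this read-out higher numbers stand for weaker inhibition and lower numbers for stronger inhibition:
- compound 1 `C[C@H](NC(=O)C(=O)NCC1(c2ccccc2)CC1)C(=O)N[C@@H](CC(=O)O)C(=O)COc1c(F)c(F)cc(F)c1F`: 27 nM
- compound 2 `Cc1cccc(CNC(=O)C(=O)N[C@@H](C)C(=O)N[C@@H](CC(=O)O)C(=O)COc2c(F)c(F)cc(F)c2F)c1`: 127 nM
- compound 3 `C[C@H](NC(=O)C(=O)NCc1ccccc1F)C(=O)N[C@@H](CC(=O)O)C(=O)COc1c(F)c(F)cc(F)c1F`: 207 nM

In this series, compound 3 gives 207 nM. The gap to compound 2 is small, with a 1.6-fold higher number from compound 2 to compound 3 (0.21 log units; within the scatter), which lies within the scatter. The gap to compound 1 is larger, with a 7.7-fold higher number from compound 1 to compound 3 (0.88 log units; beyond the scatter), which lies beyond it.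

Compound 4 `Cc1cccc(CNC(=O)C(=O)N[C@@H](C)C(=O)N[C@@H](CC(=O)O)C(=O)COc2c(F)c(F)cc(F)c2F)c1C` differs from compound 3 in one place, where 2,3-dimethylphenyl stands in place of 2-fluorophenyl on a saturated chain carbon bound to an amide-type nitrogen: 2,3-dimethylphenyl in place of 2-fluorophenyl on a saturated chain carbon bound to an amide-type nitrogen.

Within the data shown here, the closest precedent is the exchange between two substituted phenyl groups at this same place, a 1.6-fold higher number from compound 2 to compound 3 (0.21 log units; within the scatter). That step did not rise above the scatter. The larger steps, a 4.7-fold higher number from compound 1 to compound 2 (0.67 log units; beyond the scatter) and a 7.7-fold higher number from compound 1 to compound 3 (0.88 log units; beyond the scatter), both remove 1-phenylcyclopropyl, a group that plays no part in the change at hand, so they bear on it only weakly. With three compounds, this remains a thin basis.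

In this assay, no step beyond the scatter is therefore expected, and any shift should be slight and of uncertain direction. The expected step is a 1.3-fold lower number from compound 3 to compound 4 (0.11 log units; within the scatter). Compound 4 is estimated at 160 nM, with an expected range of 65 nM to 400 nM.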

Compound 4, half-maximal inhibitory concentration: 102 nM
Compound 4: middle estimate off by 1.6-fold (0.20 log units), on the high side; measured number inside the range.
By their numbers in this assay, from the lowest: compound 1; then compounds 4, 2 and 3 (each within the scatter of the next, the first and the last beyond it).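

In this assay, the exchange on a saturated chain carbon bound to an amide-type nitrogen now yields a step between two substituted phenyl groups that lies beyond the scatter, if only barely (a 2.0-fold lower number from compound 3 to compound 4 (0.31 log units; beyond the scatter)), which the earlier exchange between such groups did not. The methyl in place of hydrogen on an aromatic carbon, which alone separates 3-methylphenyl from 2,3-dimethylphenyl, stays within the scatter (a 1.2-fold lower number from compound 2 to compound 4 (0.10 log units; within the scatter)), while 1-phenylcyclopropyl keeps a margin beyond the scatter over this new group as well (a 3.8-fold higher number from compound 1 to compound 4 (0.58 log units; beyond the scatter)). Nothing available here explains any of these steps.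

On these data alone, whether a methyl or fluorine on the phenyl ring of 1-phenylcyclopropyl would shift the number in the same way as on the benzyl groups remains open. So does how this place would respond to a methoxy group or a carboxylic acid on the phenyl ring, or to a pyridine ring in place of the phenyl ring.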